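The source may hold more compounds than are shown below. What is called first, only, known or untested is meant among the compounds shown, and "the series" means these compounds.

Working notes on the series in a physicochemical assay for solubility, in phosphate buffer, measured as kinetic solubility, at pH 7.4 (a lower number here means a less soluble compound, a higher number a more soluble compound), follow. Compound 1 (`Cc1ccccc1-c1nc(CN2CCC(C(=O)NCCCN3CCC(C)CC3)CC2)c(C)o1`) gives > 67 ug/mL as a limit of the assay. Compound 2 (`Cc1ccccc1-c1nc(CN2CCC(C(=O)NCCCN3[C@H](C)CCC[C@@H]3C)CC2)c(C)o1`) gives > 69 ug/mL as a limit too. Compound 3 (`Cc1oc(-c2c(F)cccc2F)nc1CN1CCC(C(=O)NCCCN2C[C@H](C)C[C@H](C)C2)CC1`) gives > 72 ug/mL as a limit as well. Compound 2 therefore has no number and no rank among the three. Compound 4 (`Cc1ccccc1-c1nc(CN2CCC(C(=O)NCCCN3CC4CCCC(C4)C3)CC2)c(C)o1`) differs from compound 2 by one group: a group of 9 heavy atoms (8 carbon, 1 nitrogen; one six-membered non-aromatic ring of carbon only, one six-membered non-aromatic ring with 1 hetero atom) in place of a group of 8 heavy atoms (7 carbon, 1 nitrogen; one six-membered non-aromatic ring with 1 hetero atom), on a saturated chain carbon, three bonds along the chain from an amide-type nitrogen on the same chain. Going by the values given here, the only measured step that bears on this is a step that the two limits leave unreadable from compound 1 to compound 2 and it gives no size or direction to carry over. No change beyond the scatter is expected in this assay on this evidence. The expected step is a step that the limit leaves unreadable from compound 2 to compound 4 in this reading. The estimate for compound 4 is 70 ug/mL with an expected range from 45 ug/mL to 80 ug/mL and a report as a limit is likely.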

Compound 4, solubility: > 71 ug/mL
Compound 4 gave a limit, no number; the forecaster's own chance of this, stated with the estimate: 75%; middle value at least 1.0-fold (0.00 log units) away from the limit.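

Compound 1, compound 2 and compound 4 all stand as limits in this assay, and the steps to compound 4 cannot be read. The compounds shown leave open whether exchanging the group on the chain changes the read-out at all.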